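From pyridin-3-yl to pyridin-4-yl on the shared core

The compounds below may be only part of what the source reports. "The series", "measured", "known", "first", "only" and "open" are said of these compounds alone.

Of the compounds shown here, three on a shared core have been measured so far, and all three carry pyridin-3-yl. In a functional assay on SMMC-7721 cells (Homo sapiens) for cytotoxicity, read by MTT assay, with a stated time of 24 h (on this read-out higher numbers stand for weaker inhibition and lower numbers for stronger inhibition), compound 1 (`COc1cc(/C=C2\CN(C)C/C(=C\c3cccnc3)C2=O)cc(OC)c1OC`) gives 20400 nM and compound 2 (`COc1ccc(/C=C2\CN(C)C/C(=C\c3cccnc3)C2=O)c(OC)c1OC`) gives 13700 nM as its number. In this assay compound 3 (`CN1C/C(=C\c2ccc(C(F)(F)F)cc2)C(=O)/C(=C/c2cccnc2)C1`) gives 4830 nM as its number. Compound 2 therefore stands within the scatter of compound 1, while compound 3 stands beyond the scatter from compound 2, on the side of stronger inhibition.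

The next compound is compound 4 (`COc1ccc(/C=C2\CN(C)C/C(=C\c3ccncc3)C2=O)c(OC)c1OC`), which has not yet been measured. Its change from compound 2 is pyridin-4-yl in place of pyridin-3-yl on a double-bonded chain carbon bound to a double-bonded ring carbon and puts pyridin-4-yl in place of pyridin-3-yl on a double-bonded chain carbon bound to a double-bonded ring carbon. Within the data shown here, no measured pair isolates this swap, and no measured compound carries pyridin-4-yl, so the data give no direct guide to its size or direction. The expectation therefore rests on compound 2 at 13700 nM as the closest anchor. No step beyond the scatter is expected in this assay and the estimated step is a 1.1-fold lower number from compound 2 to compound 4 (0.06 log units; within the scatter) with no firm direction. For compound 4 the estimated value is 12000 nM with 6000 nM to 24000 nM as the expected range.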

Compound 4, half-maximal inhibitory concentration: 9080 nM
The estimate for compound 4 lay 1.3-fold (0.12 log units) above the measured number; low and high end bracket the measured number.
By their numbers in this assay, from the lowest: compounds 3, 4, 2 and 1 (each within the scatter of the next, the first and the last beyond it).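

In this assay, among these compounds, pyridin-4-yl in place of pyridin-3-yl on a double-bonded chain carbon bound to a double-bonded ring carbon gives a 1.5-fold lower number from compound 2 to compound 4 (0.18 log units; within the scatter), the first comparison that isolates a single place. The two groups have the same atoms and the same counts under the comparison, differing only in how the ring is joined, and with the substitution carried by compound 2 on the other side of the shared core, this assay does not separate them. At this place, therefore, this one swap of pyridine attachment does not produce a difference that can be distinguished from the usual scatter, and no measurement shown gives a reason for that result.

The compounds shown leave open whether the same swap would stay within the scatter if the other side of the shared core carried the groups of compound 1 or compound 3, since neither has a pyridin-4-yl partner here. They also leave open whether pyridin-2-yl, or a plain phenyl ring with no ring nitrogen, at this same place would give a step beyond the scatter.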